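Isobutylamino in Place of Ethoxy: Expected Cytotoxicity

The compounds below may be only part of what the source reports. "The series", "measured", "known", "first", "only" and "open" are said of these compounds alone.

Compound 1, `CCOc1nc(N)nc2c1ncn2/C=C1/CC1(CO)CO`: > 20000 nM in an ADME assay on BCBL1 cells (Homo sapiens) for cytotoxicity, with a stated time of 7 days (a lower number here means that less compound is tolerated, a higher number that more compound is tolerated), a limit of the assay.
Compound 2, `CN(C)c1nc(N)nc2c1ncn2/C=C1/CC1(CO)CO`: > 20000 nM in this assay, a limit of the assay.
Compound 3, `CC(C)Nc1nc(N)nc2c1ncn2/C=C1/CC1(CO)CO`: > 20000 nM in this assay, a limit of the assay.

Compound 1 stands at a limit in this assay; its value of > 20000 nM is the edge of what the assay reports, not a number. Among the measured compounds shown here, the same holds for every value so far: the limit of > 20000 nM in this assay, at which 3 of the 3 values shown sit. For the measured compounds named here, for that reason the steps that bear on the change at hand are unreadable. From compound 1 the steps a step that the two limits leave unreadable from compound 1 to compound 2 and a step that the two limits leave unreadable from compound 1 to compound 3 show only that replacing the ethoxy by either amino group left the compound at the same limit, and a step that the two limits leave unreadable from compound 2 to compound 3 shows the same between the two amino groups.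

The step to compound 4, `CC(C)CNc1nc(N)nc2c1ncn2/C=C1/CC1(CO)CO`, changes compound 1 as follows: isobutylamino in place of ethoxy on an aromatic carbon. Since each change at this carbon measured so far has kept the value at the limit, compound 4 is expected to do the same, so that a step that the limit leaves unreadable from compound 1 to compound 4 is expected to be no readable step. Compound 4 is estimated at 30000 nM in this assay, within a range of 15000 nM to 100000 nM.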

Compound 4, half-maximal cytotoxic concentration: > 20000 nM
Compound 4 gave a limit, no number; the forecaster's own chance of this, stated with the estimate: 85%; the middle value is on the limit's open side.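

Compound 4 also stands at a limit in this assay, so none of the steps from compound 1, compound 2 or compound 3 to compound 4 can be read: the limit of > 20000 nM in this assay, at which 4 of the 4 values shown sit.

The compounds shown leave open whether the ethoxy, dimethylamino, isopropylamino and isobutylamino compounds differ at all in cytotoxicity, and at what concentration any of them becomes cytotoxic.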